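The source may hold more compounds than are shown below. What is called first, only, known or untested is meant among the compounds shown, and "the series" means these compounds.

Measured compounds:
- compound 1 `Oc1ccc(-c2cc(-c3ccco3)nc(-c3ccccc3Cl)c2)cc1`: 3.9%
- compound 2 `Oc1ccc(-c2cc(-c3ccc(Cl)cc3)nc(-c3ccsc3)c2)cc1`: 47.7%
- compound 3 `Oc1cccc(-c2cc(-c3ccc(Cl)cc3)nc(-c3ccco3)c2)c1`: 27.1%

All three were tested in an assay on isolated protein for inhibition of DNA topoisomerase 1 (Homo sapiens), with a stated time of 30 min, tested at 100 uM; on this read-out lower numbers stand for a weaker effect and higher numbers for a stronger effect at the one concentration tested. Compound 3 stands second highest of the three numbers. Its nearest neighbour is compound 2, whose number is higher by a margin beyond the usual scatter, and its furthest is compound 1, whose number is lower, again beyond the scatter. Among the measured compounds shown here, no single-change step between the measured compounds is available, so these gaps are read only as what the two values show, not as the effect of any one change.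

The next compound, compound 4 `Oc1ccc(-c2cc(-c3ccc(Cl)cc3)nc(-c3ccco3)c2)cc1`, keeps the same atoms as compound 3 but joins them differently: 4-hydroxyphenyl in place of 3-hydroxyphenyl on an aromatic carbon. The hydroxyl group moves to another position on the same ring, while the 4-chlorophenyl and furan-2-yl groups on the shared core stay put.

Without a measured step for this kind of change, the expected size of the step from compound 3 to compound 4 is small, probably within the scatter, with at most a modest rise. Compound 4 is estimated at 33%, in a range from 12% to 58%, which means a step of a number 5.9 percentage points higher from compound 3 to compound 4 (within the scatter) is expected.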

Compound 4, a percentage reported as inhibition, at one concentration (the size of the read-out at that concentration, not a potency): 15.8%
Estimate against measurement, compound 4: 17.2 percentage points above; the range from low to high includes it.
By their numbers in this assay, from the lowest: compound 1; then compound 4; then compound 3; then compound 2.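

In this assay the group opposite the ring nitrogen proves sensitive to where its hydroxyl sits: with 4-hydroxyphenyl in place of 3-hydroxyphenyl there is a number 11.3 percentage points lower from compound 3 to compound 4 (beyond the scatter) and not the same number, so two groups with the same atom counts do not behave alike here. Among the compounds shown here, compound 4 also links the earlier compounds for the first time, and the two other groups on the shared core matter as well, with furan-2-yl in place of thiophen-3-yl showing a number 31.9 percentage points lower from compound 2 to compound 4 (beyond the scatter) as a large step and 4-chlorophenyl in place of 2-chlorophenyl showing a number 11.9 percentage points higher from compound 1 to compound 4 (beyond the scatter) as a modest one. Nothing measured here accounts for the direction or size of any of these steps.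

Going by these compounds, whether the hydroxyl is needed at all stays open, as does what an amine or a carboxylic acid would do in its place on this ring. On these data alone, it is also open whether moving the hydroxyl has the same result with thiophen-3-yl or 2-chlorophenyl on the shared core, as each change here rests on a single pair of compounds.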